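Bromo for chloro at the assay limit

The compounds below may be only part of what the source reports. "The series", "measured", "known", "first", "only" and "open" are said of these compounds alone.

In a functional assay on MDA-MB-231 cells (Homo sapiens) for antiproliferative activity, read by MTT assay, with a stated time of 48 h (on this read-out higher numbers stand for weaker inhibition and lower numbers for stronger inhibition), compound 1 `CN1C(=O)C(O)(Cc2nnn[nH]2)c2ccccc21` gives > 100000 nM, which is a limit and not a number. In this assay compound 2 `CN1C(=O)C(O)(Cc2nnn[nH]2)c2cc(Cl)ccc21` gives > 100000 nM, which is likewise a limit. Compound 2 therefore has no numerical standing in the series, and the evidence so far is the limit of > 100000 nM in this assay, at which 2 of the 2 values shown sit.

Compound 3 `CN1C(=O)C(O)(Cc2nnn[nH]2)c2cc(Br)ccc21` carries bromo in place of the chloro of compound 2: bromo in place of chloro on an aromatic carbon.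

For the measured compounds named here, the only measured step bearing on this change is a step that the two limits leave unreadable from compound 1 to compound 2, where chloro takes the place of hydrogen on an aromatic carbon. It gives no size to carry over. No step beyond the scatter is expected in this assay, and no direction is expected. The estimated step is a step that the limit leaves unreadable from compound 2 to compound 3. Compound 3 is estimated at 120000 nM, with an expected range of 50000 nM to 300000 nM.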

Compound 3, half-maximal inhibitory concentration: 67300 nM
Beside the measured number, compound 3's estimate is 1.8-fold (0.25 log units) above it, within the range that was stated.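

For the compounds shown here, compound 3 is the first compound to carry a number rather than a limit in this assay, so this position on the core of compound 1 now has one readable value. Bromo in place of chloro gives an at least 1.4-fold lower number from compound 2 to compound 3 (0.17 log units; that floor lies within the scatter) and bromo in place of hydrogen gives an at least 1.4-fold lower number from compound 1 to compound 3 (0.17 log units; that floor lies within the scatter) and each of these is only a floor, so neither step is shown to lie beyond the scatter and the true size of both remains unknown. The series still rests largely on one boundary: the limit of > 100000 nM in this assay, at which 2 of the 3 values shown sit.

Going by these compounds, the step from compound 1 to compound 2 cannot be read, so the size of chloro in place of hydrogen stays open. Also open, on these data alone, is how an amine or a methoxy group would read at this same position, and whether any group placed here would give a step clearly beyond the scatter.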